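This account rests on a few compounds, and the source may have more. Where it says the series, first, only, none or still open, it means among the compounds named here.

Three measured compounds share one core. In a functional assay on A549 cells (Homo sapiens) for cytotoxicity, read by MTT assay, with a stated time of 72 h (on this read-out higher numbers stand for weaker inhibition and lower numbers for stronger inhibition), compound 1 `CC(=O)n1cc(/C=C(/C(=O)O)c2ccccc2)c2cc(OCc3ccccc3)ccc21` gives 57500 nM. In this assay compound 2 `COc1ccc(/C(=C\c2c[nH]c3ccc(OCc4ccccc4)cc23)C(=O)O)cc1` gives "not determined" (no result reported), so no number stands for it. Compound 3 `COc1ccccc1/C(=C\c1cn(C(C)=O)c2ccc(OCc3ccccc3)cc12)C(=O)O` gives 57200 nM in this assay; it carries a methoxy where compound 1 carries hydrogen, and the two numbers stand within the usual scatter of each other. Compound 4 `COc1ccc(OC)c(/C(=C\c2cn(C(C)=O)c3ccc(OCc4ccccc4)cc23)C(=O)O)c1` differs from compound 3 by methoxy in place of hydrogen on an aromatic carbon. Among the measured compounds shown here, the only comparable step, a 1.0-fold lower number from compound 1 to compound 3 (0.00 log units; within the scatter), also added a methoxy and produced nothing beyond the scatter. A second methoxy is therefore expected to leave the number essentially where it is, an expected step of a 1.0-fold lower number from compound 3 to compound 4 (0.00 log units; within the scatter) in this assay. Compound 4 is estimated at 57000 nM, with a range from 25000 nM to 130000 nM.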

Compound 4, half-maximal inhibitory concentration: 54500 nM
Compound 4: the middle estimate sits 1.0-fold (0.02 log units) above what was measured; the measured number falls inside the stated range.
By their numbers in this assay, from the lowest: compounds 4, 3 and 1 (each within the scatter of the next).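

The 2,5-dimethoxyphenyl of compound 4 stands level with the 2-methoxyphenyl of compound 3, with a 1.0-fold lower number from compound 3 to compound 4 (0.02 log units; within the scatter). Against the plain phenyl the picture is the same, with a 1.1-fold lower number from compound 1 to compound 4 (0.02 log units; within the scatter), so neither one methoxy nor two on this ring moves the number beyond the scatter. No evidence is available to explain this flat result. On these data alone, whether an amine, a carboxylic acid or a longer chain on this ring would shift the number stays open.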